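The source may report more compounds than this note shows. Statements on the series, on what has been measured and on what is new or still open speak of the compounds shown alone.

Compound 2 `COc1ccc(C(=O)/C=C/c2cc(-c3cc(OC)c(OC)c(OC)c3)n[nH]2)cc1OC` is the lower of the two numbers recorded in a functional assay on Hs-578T cells (Homo sapiens) for inhibition, read by sulforhodamine B assay, with a stated time of 48 h (a higher number here means a weaker inhibitor of growth, a lower number a stronger inhibitor of growth), and there compound 2 gives 2570 nM. Among the compounds with values here, its only comparator is compound 1 `COc1cc(-c2cc(/C=C/C(=O)c3ccc(Cl)c(Cl)c3)[nH]n2)cc(OC)c1OC`, which in this assay gives 16600 nM; the single step between them, a 6.5-fold lower number from compound 1 to compound 2 (0.81 log units; beyond the scatter), reflects a change on the carbonyl carbon and is the only measured step in this set.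

Compound 3 `COc1ccc(C(=O)/C=C/c2cc(-c3cc(OC)c(OC)c(OC)c3)n[nH]2)cc1` differs from compound 2 in one place: hydrogen in place of methoxy on an aromatic carbon. The step from compound 1 to compound 2 bears on this change only loosely, since it also altered the ring on the carbonyl carbon, exchanging two chlorines for two methoxy groups rather than removing one methoxy. Nothing measured here shows what a single methoxy removal does on this ring. The methoxy that enters in that step seems to have helped, so losing one of the pair is expected to cost a little, probably a shift no larger than the scatter, a 1.8-fold higher number from compound 2 to compound 3 (0.24 log units; within the scatter). Compound 3 is therefore expected to give about 4500 nM in this assay, within 1500 nM to 14000 nM.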

Compound 3, concentration for 50% growth inhibition: 3600 nM
Compound 3: the middle estimate sits 1.3-fold (0.10 log units) above what was measured; the measured number falls inside the stated range.
By their numbers in this assay, from the lowest: compounds 2 and 3 (each within the scatter of the next); then compound 1.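

In this assay, taking one methoxy off the ring on the carbonyl carbon, the change from 3,4-dimethoxyphenyl to 4-methoxyphenyl, gives a 1.4-fold higher number from compound 2 to compound 3 (0.15 log units; within the scatter), so the methoxy at this place, ortho to a methoxy group, is not shown to matter for growth inhibition. The ring with a single methoxy still stands clearly apart from the 3,4-dichlorophenyl ring, with a 4.6-fold lower number from compound 1 to compound 3 (0.66 log units; beyond the scatter), so the separation first seen as a 6.5-fold lower number from compound 1 to compound 2 (0.81 log units; beyond the scatter) does not need the second methoxy, at least within what this assay can resolve. Nothing among the available data bears on why these numbers fall as they do.

The compounds shown leave open what the methoxy remaining in compound 3 contributes, and whether a hydroxy group, an amine, a single chlorine or a longer ethoxy chain in its place would leave the number where it stands. They also leave open whether hydrogen and methoxy would remain indistinguishable at this place on the ring in other cells.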